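A few compounds are considered here, and "the series" means these few. Any claim that something is new, unique, unknown or untested is made for them only; others in the source may bear on it.

Compound 1 `COc1cc(Nc2nc3ccccc3nc2S(=O)(=O)c2ccc(C)cc2)cc(OC)c1`: > 50000 nM
Compound 2 `Cc1ccc(S(=O)(=O)c2nc3ccccc3nc2Nc2ccc(N)cc2)cc1`: 11500 nM
Compound 3 `COc1cc(Nc2nc3ccccc3nc2S(=O)(=O)c2ccc(F)cc2)cc(OC)c1`: 3930 nM

In a functional assay on HCT-116 cells (Homo sapiens) for cytotoxicity, read by MTT assay, with a stated time of 72 h (a higher number here means a weaker inhibitor, a lower number a stronger inhibitor), the value of compound 1, > 50000 nM, is a limit of the assay rather than a number, namely (the limit of > 50000 nM in this assay, at which 1 of the 3 values shown sits). Compound 2 differs from compound 1 by 4-aminophenyl in place of 3,5-dimethoxyphenyl on a nitrogen on an aromatic ring, and that change brought an at least 4.3-fold lower number from compound 1 to compound 2 (0.63 log units; beyond the scatter). Compound 3 differs from compound 1 in its core by fluoro in place of methyl on an aromatic carbon, which gave an at least 12-fold lower number from compound 1 to compound 3 (1.10 log units; beyond the scatter). Among the numbers in hand, compound 3 sits lowest, with compound 2 the nearest at a higher value.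

Compound 4 `Nc1ccc(Nc2nc3ccccc3nc2S(=O)(=O)c2ccc(F)cc2)cc1` has not yet been tested. It differs from compound 3 by 4-aminophenyl in place of 3,5-dimethoxyphenyl on a nitrogen on an aromatic ring, the same change as that between compound 1 and compound 2, made on the same place. Given that this change already produced an at least 4.3-fold lower number from compound 1 to compound 2 (0.63 log units; beyond the scatter), and that compound 3 stands at 3930 nM, compound 4 is expected to show a 3.9-fold lower number from compound 3 to compound 4 (0.59 log units; beyond the scatter). Compound 4 is therefore estimated at 1000 nM, with the expected range running from 300 nM to 3500 nM.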

Compound 4, half-maximal inhibitory concentration: 10100 nM
Beside the measured number, compound 4's estimate is 10-fold (1.00 log units) below it; the whole stated range lies below it.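

In this assay, placing 4-aminophenyl for 3,5-dimethoxyphenyl on the fluoro-bearing compounds gave a 2.6-fold higher number from compound 3 to compound 4 (0.41 log units; beyond the scatter), so the change did not carry over from the methyl-bearing pair in the same direction: the same change on two cores in this assay, an at least 4.3-fold lower number (0.63 log units; beyond the scatter) from compound 1 to compound 2 and a 2.6-fold higher number (0.41 log units; beyond the scatter) from compound 3 to compound 4, at least 11-fold (1.04 log units) apart, beyond the scatter of two such steps. The other change behaved in the same way, since fluoro in place of methyl gave a 1.1-fold lower number from compound 2 to compound 4 (0.06 log units; within the scatter) with 4-aminophenyl on the nitrogen, and the step seen with 3,5-dimethoxyphenyl did not carry over: the same change on two cores in this assay, an at least 12-fold lower number (1.10 log units; beyond the scatter) from compound 1 to compound 3 and a 1.1-fold lower number (0.06 log units; within the scatter) from compound 2 to compound 4, at least 11-fold (1.04 log units) apart, beyond the scatter of two such steps. These four compounds show that neither change can be read apart from the group at the other place, but they give no rule for other cores or the reason for this, and the earlier step of each comparison rests on compound 1, whose value of > 50000 nM is a limit of the assay and not a number.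

The compounds shown leave open whether this dependence would persist with chloro in place of fluoro, or with a carboxylic acid or a longer chain in place of 4-aminophenyl.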